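This account rests on a few compounds, and the source may have more. Where it says the series, first, only, none or still open, it means among the compounds named here.

Of the compounds shown here, two have so far been measured in a functional assay on the whole organism (strain albino) for inhibition, with Rattus norvegicus as the target, read by paw edema, with a stated time of 1 h, at a dose of 0.28 mmol/kg by the oral route; on this read-out lower numbers stand for less inhibition and higher numbers for more inhibition at the one dose given (going by the name of the read-out). Compound 1, with the structure `C=CCn1c(SC/C(=N/O)c2ccccc2)nnc1-c1ccc(OC)cc1`, gives 61% in this assay. Compound 2, with the structure `CCn1c(SC/C(=N/O)c2ccccc2)nnc1-c1ccc(OC)c(OC)c1`, gives 61% in this assay. Compound 2 therefore stands level with compound 1 at the digits shown; compound 1 is its nearest measured neighbour, and the two values lie within the usual scatter of repeated measurements, so nothing can be said about one being higher or lower than the other.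

Compound 3, with the structure `CCn1c(SC/C(=N/O)c2ccccc2)nnc1-c1ccc(OC)cc1`, has not yet been measured in this assay. It differs from compound 2 in one place: hydrogen in place of methoxy on an aromatic carbon. Among the compounds with values here, no step between two measured compounds that differ in only one place is available, so there is no measured guide for what this single change does; compound 1 and compound 2 differ in more than one place and simply sit at the same level.

With both measured compounds at one level, the change is expected to bring no shift beyond the scatter, so the step from compound 2 to compound 3 is expected to be a number 1 percentage points lower from compound 2 to compound 3 (within the scatter). In this assay compound 3 is expected to give about 60%, within a range from 45% to 73%.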

Compound 3, a percentage reported as inhibition, in the whole organism at one dose (the size of the read-out at that dose, not a potency): 69%
Beside the measured number, compound 3's estimate is 9 percentage points below it; the measured number falls inside the stated range.
By their numbers in this assay, from the lowest: compounds 1, 2 and 3 (each within the scatter of the next).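

Within the data shown here, these are the first comparisons of compounds that differ in one place only. In this assay, hydrogen in place of methoxy on an aromatic carbon of the six-membered ring gives a number 8 percentage points higher from compound 2 to compound 3 (within the scatter), so at this dose the read-out does not show that this methoxy group is needed to hold the level of inhibition. On the chain bound to an aromatic nitrogen, methyl in place of vinyl gives a number 8 percentage points higher from compound 1 to compound 3 (within the scatter), so this small change at the end of the chain also shifts nothing beyond the scatter, and no measurement here explains either result.

As far as these compounds go, both comparisons cover only a narrow choice of groups, so it remains open whether an amine or a carboxylic acid on that aromatic carbon, or a longer chain such as butyl on the aromatic nitrogen, would keep the same level or move it clearly. With a single dose and a single time, these numbers also leave open how the compounds would rank across other doses, since the size of the read-out at one dose is not a potency.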